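The compounds below may be only part of what the source reports. "The series", "measured", "known", "first", "only" and "open" are said of these compounds alone.

Compound 2 `CC1=C(/C=C/C(=O)/C=C/c2ccc(C#N)cc2)C(C)(C)CCC1` is the weaker of the two measured entries so far: in a functional assay on PC-3 cells (Homo sapiens) for cytotoxicity, read by sulforhodamine B assay, with a stated time of 48 h (on this read-out lower numbers stand for stronger inhibition and higher numbers for weaker inhibition), compound 2 gives 11900 nM, the highest of the two numbers, with compound 1 `CC1=C(/C=C/C(=O)/C=C/c2ccc(Cl)cc2)C(C)(C)CCC1` nearest at 9500 nM. The step between them, a 1.3-fold higher number from compound 1 to compound 2 (0.10 log units; within the scatter), was a swap of cyano for chloro on the aromatic carbon and did not reach beyond the scatter. The next compound, compound 3 `CC1=C(/C=C/C(=O)/C=C/c2ccc([N+](=O)[O-])cc2)C(C)(C)CCC1`, changes the same position once more: nitro in place of cyano on an aromatic carbon. Among the compounds with values here, only one measured step bears on this change, the one from compound 1 to compound 2, since it is the sole example here of exchanging the group on that aromatic carbon, and it moved the number by little. With nothing in the data to suggest that a nitro group behaves differently from the chloro or cyano already seen, the account expects no step beyond the scatter for compound 3, a change of about a 1.1-fold lower number from compound 2 to compound 3 (0.03 log units; within the scatter) in this assay. Compound 3 is therefore estimated at 11000 nM, with a range from 5000 nM to 25000 nM.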

Compound 3, half-maximal inhibitory concentration: 1900 nM
Compound 3: middle estimate off by 5.8-fold (0.76 log units), on the high side; measured number below the stated range.
By their numbers in this assay, from the lowest: compound 3; then compounds 1 and 2 (each within the scatter of the next).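

In this assay the group on this aromatic carbon, para to a large group, proves able to shift the number after all: the exchange for nitro gives a 6.3-fold lower number from compound 2 to compound 3 (0.80 log units; beyond the scatter) when cyano leaves and a 5.0-fold lower number from compound 1 to compound 3 (0.70 log units; beyond the scatter) when chloro leaves, while the earlier exchange, a 1.3-fold higher number from compound 1 to compound 2 (0.10 log units; within the scatter) on swapping chloro for cyano, stayed within the scatter. The position is therefore not indifferent to what sits on it, and the three compounds fall into two tiers, with compound 3 alone at the low end and compounds 1 and 2 within the scatter of each other. Nothing at hand explains why nitro parts from the other two groups.

What the compounds shown leave open is whether this low end belongs to nitro alone, or whether an amine, a carboxylic acid or a methoxy group on the same aromatic carbon would join compound 3 rather than compounds 1 and 2. On these data alone, it also remains open whether nitro would keep this advantage at another place on the ring, or in cells other than these.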